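Chloro for amino on the shared core: growth inhibition

The source may report more compounds than this note shows. Statements on the series, on what has been measured and on what is new or still open speak of the compounds shown alone.

Compound 1 `Nc1nc(Cl)c2ncn(Cc3ccccc3CCl)c2n1` gives 20000 nM in a functional assay on OVCAR-3 cells (Homo sapiens) for cytotoxicity, read by sulforhodamine B assay, with a stated time of 48 h; a lower number here means a stronger inhibitor of growth, a higher number a weaker inhibitor of growth. Compound 2 `ClCc1ccccc1Cn1cnc2nc(Cl)nc(Cl)c21` gives 27500 nM in this assay. Compound 1 holds the lowest of the two numbers, though the gap to compound 2 lies within the scatter. Compound 3 `ClCc1ccccc1Cn1cnc2c(Cl)nc(Cl)nc21` differs from compound 1 by chloro in place of amino on an aromatic carbon. For the measured compounds named here, no measured pair shows this change, so the expected step of a 1.3-fold higher number from compound 1 to compound 3 (0.10 log units; within the scatter) is small, upward if anything and not beyond the scatter, because compound 2 gives 27500 nM. Compound 3 is expected to give 25000 nM in this assay, within 10000 nM to 60000 nM.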

Compound 3, concentration for total growth inhibition: 510 nM
The estimate for compound 3 lay 49-fold (1.69 log units) above the measured number, and the stated range ends above it.
By their numbers in this assay, from the lowest: compound 3; then compounds 1 and 2 (each within the scatter of the next).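

In this assay, chloro in place of amino on the aromatic carbon between two ring nitrogen atoms gives a 39-fold lower number from compound 1 to compound 3 (1.59 log units; beyond the scatter), so this position on the shared core responds strongly to this change. For the compounds shown here, compound 1 and compound 2, whose numbers lie within the scatter of each other, gave no sign of a step this large. Nothing measured here accounts for its size.

Still open, going by these compounds, is whether the step is specific to chloro or would also appear with hydrogen, methyl, methoxy or bromo at this carbon. Also open, on these data alone, is whether a secondary amine there would behave like amino.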